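The compounds below may be only part of what the source reports. "The series", "measured", "known", "first", "only" and "open" are said of these compounds alone.

Measured in an ADME assay on LLC-PK1 cells (Sus scrofa) for permeability (on this read-out lower numbers stand for lower permeability and higher numbers for higher permeability), so far:
- compound 1 `CCOc1cnc(C(=O)Nc2cc(F)c(F)c([C@@]3(C)N=C(N)S[C@@]4(COC)C[C@H]43)c2)cn1` gives 25 10^-6 cm/s
- compound 2 `COC[C@]12C[C@H]1[C@@](C)(c1cc(NC(=O)c3cnc(OCC(F)(F)F)cn3)cc(F)c1F)N=C(N)S2` gives 25 10^-6 cm/s
- compound 3 `CCCOc1cnc(C(=O)Nc2cc(F)c(F)c([C@@]3(C)N=C(N)S[C@@]4(COC)C[C@H]43)c2)cn1` gives 18 10^-6 cm/s

Compound 3 sits within the scatter of both other compounds. Compound 4 `COC[C@]12C[C@H]1[C@@](C)(c1cc(NC(=O)c3cnc(OCc4ncco4)cn3)cc(F)c1F)N=C(N)S2` carries 1,3-oxazol-2-yl in place of ethyl on a saturated chain carbon bound to an oxygen on an aromatic ring.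

Three measured steps change this same chain: no change at the digits printed from compound 1 to compound 2 (within the scatter), a 1.4-fold lower number from compound 1 to compound 3 (0.14 log units; within the scatter) and a 1.4-fold lower number from compound 2 to compound 3 (0.14 log units; within the scatter). All stay within the scatter, but none brings in a ring, so they are only a loose guide here. In this assay no shift beyond the scatter is expected, and the expected step is a 1.2-fold lower number from compound 3 to compound 4 (0.08 log units; within the scatter). For compound 4 the estimate is 15 10^-6 cm/s, with an expected range of 8 10^-6 cm/s to 27 10^-6 cm/s.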

Compound 4, apparent permeability: 48 10^-6 cm/s
For compound 4 the middle estimate is 3.2-fold (0.51 log units) below the measured one; measured number outside the range, above it.
By their numbers in this assay, from the lowest: compounds 3, 1, 2 and 4 (each within the scatter of the next, the first and the last beyond it).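

First ring at this place, on a saturated chain carbon bound to an oxygen on an aromatic ring: in this assay, 1,3-oxazol-2-yl gives a 2.7-fold higher number from compound 3 to compound 4 (0.43 log units; beyond the scatter), the first step in the set beyond the scatter. Against the other two chains it stays within the scatter, with a 1.9-fold higher number from compound 2 to compound 4 (0.28 log units; within the scatter) and a 1.9-fold higher number from compound 1 to compound 4 (0.28 log units; within the scatter), so the ring shows no loss on this read-out and only the comparison with ethyl separates. No available evidence accounts for the step.

Open: whether phenyl, a ring without hetero atoms, or an amine on the same chain carbon would read like 1,3-oxazol-2-yl.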